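The compounds below may be only part of what the source reports. "The series", "measured", "known", "first", "only" and "open" are said of these compounds alone.

Three compounds of the series have a number in a functional assay on MCF7 cells (Homo sapiens) for cytotoxicity, read by MTT assay, with a stated time of 24 h, tested at 6.4 ug/mL; a lower number here means a weaker effect, a higher number a stronger effect of the compound at the concentration tested. Compound 1 `Cn1c(-c2ccc(NC(=O)CCl)cc2)nc(-c2ccccc2)c1-c1ccccc1` gives 14.2%. Compound 2 `Cn1c(-c2ccc(NC(=O)CSc3nc4cc(Cl)ccc4o3)cc2)nc(-c2ccccc2)c1-c1ccccc1` gives 27.7%, and compound 3 `Cn1c(-c2ccc(NC(=O)CSc3nc4ccccc4s3)cc2)nc(-c2ccccc2)c1-c1ccccc1` gives 27%. Compound 2 holds the highest number of the three, but its nearest neighbour is compound 3, a number 0.7 percentage points lower from compound 2 to compound 3 (within the scatter), so the two cannot be ordered; compound 1 lies furthest off, a number 13.5 percentage points higher from compound 1 to compound 2 (beyond the scatter). Compound 3 likewise stands above compound 1, a number 12.8 percentage points higher from compound 1 to compound 3 (beyond the scatter).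

Compound 4 `CCN1CCN(CC(=O)Nc2ccc(-c3nc(-c4ccccc4)c(-c4ccccc4)n3C)cc2)CC1` has not yet been measured in this assay. It differs from compound 2 in one place: 4-ethylpiperazin-1-yl in place of (5-chloro-1,3-benzoxazol-2-yl)sulfanyl on a saturated chain carbon bound to a carbonyl carbon. Within the data shown here, no measured step makes this exchange. Among the measured compounds shown here, the steps that bear on it are the two from compound 1, each replacing chloro at the same saturated chain carbon with a sulfur-linked bicyclic aromatic group, and each was modest and beyond the scatter. The exchange of one such bicyclic group for another, from compound 2 to compound 3, stayed within the scatter. For an entering saturated ring with two nitrogens there is no measured guide. The step from compound 2 to compound 4 is therefore expected to be a number 7.7 percentage points lower from compound 2 to compound 4 (within the scatter), leaning downward toward compound 1 but with wide uncertainty. For compound 4 the value in this assay is estimated at 20%, within 8% to 34%.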

Compound 4, a percentage reported as activity, at one concentration (the size of the read-out at that concentration, not a potency): 16.4%
Beside the measured number, compound 4's estimate is 3.6 percentage points above it; low and high end bracket the measured number.
By their numbers in this assay, from the lowest: compounds 1 and 4 (each within the scatter of the next); then compounds 3 and 2 (each within the scatter of the next).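

At the saturated chain carbon bound to a carbonyl carbon, in this assay, 4-ethylpiperazin-1-yl does not hold the level of the sulfur-linked bicyclic groups: a number 11.3 percentage points lower from compound 2 to compound 4 (beyond the scatter), and likewise a number 10.6 percentage points lower from compound 3 to compound 4 (beyond the scatter). Against chloro at the same carbon, the same exchange gives a number 2.2 percentage points higher from compound 1 to compound 4 (within the scatter), so the rise seen with the two sulfur-linked groups does not appear with every larger group placed here, and compound 1 and compound 4 cannot be ordered. Among these four compounds, compound 2 and compound 3 form the upper pair and compound 1 and compound 4 the lower pair, with no compound going against that split, and no measurement at hand offers an explanation for it.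

The sulfur link and the bicyclic aromatic ring change together in compound 2 and compound 3, so the series does not yet show which of the two goes with the higher number; a phenylsulfanyl group, or a 1,3-benzothiazol-2-yl group bound directly to the chain carbon, would separate them. Going by these compounds, whether the lower number extends to other saturated rings, such as morpholin-4-yl or piperidin-1-yl, also remains open, as does the behaviour of a simple amine such as dimethylamino.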